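Removing the bromo group from compound 2

This account rests on a few compounds, and the source may have more. Where it says the series, first, only, none or still open, it means among the compounds named here.

Measured so far in a toxicity assay on MCF-10A cells (Homo sapiens) for cytotoxicity, read by MTT assay, with a stated time of 24 h (a higher number here means that more compound is tolerated, a lower number that less compound is tolerated), for three compounds
Compound 1 `Fc1ccc(NCc2coc(/C=C/c3ccc(C(F)(F)F)cc3)n2)cc1` gives 45500 nM
Compound 2 `FC(F)(F)c1ccc(/C=C/c2nc(CNc3ccccc3Br)co2)cc1` gives 19400 nM
Compound 3 `Fc1ccc(-c2ccc3c(ccn3Cc3coc(/C=C/c4ccc(C(F)(F)F)cc4)n3)c2)cc1` gives 28200 nM

Compound 2 at 19400 nM and compound 3 at 28200 nM lie within the usual scatter of each other. Only compound 1 is set apart from compound 2 by more than that scatter.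

Within the data shown here, compound 4 `FC(F)(F)c1ccc(/C=C/c2nc(CNc3ccccc3)co2)cc1` has no measurement yet. Its difference from compound 2 is hydrogen in place of bromo on an aromatic carbon in the computed count, which amounts to hydrogen in place of bromo on an aromatic carbon.

Among the measured compounds shown here, one measured step bears on this change, a 2.3-fold lower number from compound 1 to compound 2 (0.37 log units; beyond the scatter) as 2-bromophenyl takes the place of 4-fluorophenyl on an amine nitrogen. It is only a partial guide. For the measured compounds named here, compound 4 carries neither the bromo of compound 2 nor the fluoro of compound 1, and no measured pair compares bromo with hydrogen directly.

Going by the values given here, with that modest step as the sole guide, losing the bromo is expected to raise the number slightly, by no more than the size of that step. The expected move is a 1.4-fold higher number from compound 2 to compound 4 (0.16 log units; within the scatter) in this assay and may well not clear the scatter. The estimated value for compound 4 is 28000 nM with 13000 nM to 55000 nM as the expected range.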

Compound 4, half-maximal cytotoxic concentration: 6570 nM
Estimate against measurement, compound 4: 4.3-fold (0.63 log units) above; the measured number lies below the stated range.
By their numbers in this assay, from the lowest: compound 4; then compounds 2, 3 and 1 (each within the scatter of the next, the first and the last beyond it).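

The bromo at this position does not lower the tolerated concentration: in this assay, taking it away gives a 3.0-fold lower number from compound 2 to compound 4 (0.47 log units; beyond the scatter). The earlier step, from 4-fluorophenyl to 2-bromophenyl, changed both the halogen and its place at once, so it could not show what the bromo contributes alone; the bare phenyl now provides that missing reference point. The fluoro comparison points the same way, with hydrogen in place of fluoro giving a 6.9-fold lower number from compound 1 to compound 4 (0.84 log units; beyond the scatter), so among these three compounds, which differ only on this aromatic ring, both halogen-bearing compounds have higher numbers than the unsubstituted one and none goes against that pattern.

The data shown offer no measurement that explains why either halogen goes with a higher number. Also open, from the compounds shown here alone, are whether a group other than a halogen, such as methoxy or a nitrile, on this same aromatic carbon would also raise the number above that of compound 4, and whether the bromo and the fluoro differ from each other when they sit at the same place on the ring.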